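This account rests on a few compounds, and the source may have more. Where it says the series, first, only, none or still open, it means among the compounds named here.

Going by the values given here, in a functional assay on MCF7 cells (Homo sapiens) for antiproliferative activity, read by MTT assay, with a stated time of 48 h (a lower number here means a stronger inhibitor, a higher number a weaker inhibitor), compound 2 `COc1ccc2[nH]c(-c3cn(-c4ccccc4)nc3-c3ccc(F)cc3)nc2c1` gives 970 nM, the lower of the two numbers so far, and compound 1 `O=C(OCc1ccccc1)c1ccc2[nH]c(-c3cn(-c4ccccc4)nc3-c3ccccc3)nc2c1` gives 12600 nM, a gap beyond the usual scatter. Compound 3 `O=C(OCc1ccccc1)c1ccc2[nH]c(-c3cn(-c4ccccc4)nc3-c3ccc(F)cc3)nc2c1` differs from compound 2 in one place: benzyloxycarbonyl in place of methoxy on an aromatic carbon. Among the compounds with values here, no measured pair shows this change alone. Compound 1 also carries benzyloxycarbonyl and sits at 12600 nM, which points towards a weaker inhibitor. The expected change in this assay is a rise beyond the scatter, estimated as a 5.2-fold higher number from compound 2 to compound 3 (0.71 log units; beyond the scatter). The estimate for compound 3 is 5000 nM, with a range from 1300 nM to 19000 nM.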

Compound 3, half-maximal inhibitory concentration: 9240 nM
For compound 3 the middle estimate is 1.8-fold (0.27 log units) below the measured one; the measured number falls inside the stated range.
By their numbers in this assay, from the lowest: compound 2; then compounds 3 and 1 (each within the scatter of the next).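

In this assay, going by these compounds alone, benzyloxycarbonyl in place of methoxy on this aromatic carbon gives a 9.5-fold higher number from compound 2 to compound 3 (0.98 log units; beyond the scatter), the first reading of this change alone, and it shows a loss of activity with the fluoro group held constant. With benzyloxycarbonyl kept, fluoro in place of hydrogen gives a 1.4-fold lower number from compound 1 to compound 3 (0.13 log units; within the scatter), which lies within the scatter. No supporting data explain the loss seen with benzyloxycarbonyl.

On these data alone, whether a carboxylic acid or an amine on this carbon would stay closer to compound 2 remains open. So does whether fluoro matters when methoxy is present.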